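Adding a Methoxy Group to the Phenyl on the Core

The source may hold more compounds than are shown below. What is called first, only, known or untested is meant among the compounds shown, and "the series" means these compounds.

Compound 1 `COc1ccccc1N1CCN(CCn2c(=O)[nH]c3cc(-c4ccccc4)[nH]c3c2=O)CC1`: in an assay for binding affinity to Adrenergic receptor alpha-1 (Rattus norvegicus) (on this read-out lower numbers stand for stronger inhibition and higher numbers for weaker inhibition), compound 1 gives 0.52 nM.
Compound 2 `O=c1[nH]c2cc(-c3ccccc3)[nH]c2c(=O)n1CCN1CCN(c2ccccc2Cl)CC1`: in this assay compound 2 gives 1.08 nM.
Compound 3 `COc1ccc(N2CCN(CCn3c(=O)[nH]c4cc(-c5ccccc5)[nH]c4c3=O)CC2)cc1`: in this assay compound 3 gives > 10000 nM, which is a limit of the assay and not a number (the limit of > 10000 nM in this assay, at which 1 of the 3 values shown sits).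

Among the two numbers shown, compound 2 gives the higher one; the nearest is compound 1, reached by a 2.1-fold higher number from compound 1 to compound 2 (0.32 log units; beyond the scatter). The shift to a 4-methoxyphenyl on the ring nitrogen, an at least 19000-fold higher number from compound 1 to compound 3 (4.28 log units; beyond the scatter) and an at least 9200-fold higher number from compound 2 to compound 3 (3.96 log units; beyond the scatter), only reaches the limit.

Compound 4 `COc1ccc(-c2cc3[nH]c(=O)n(CCN4CCN(c5ccccc5Cl)CC4)c(=O)c3[nH]2)cc1` differs from compound 2 by methoxy in place of hydrogen on an aromatic carbon. Among the measured compounds shown here, none of the measured steps touches this phenyl on the core; all three alter the aryl on the ring nitrogen. For the measured compounds named here, with no step bearing on this position, a change no larger than the usual scatter is expected for compound 4 in this assay, so the step of a 1.4-fold higher number from compound 2 to compound 4 (0.14 log units; within the scatter) is expected to be small. Compound 4 is estimated at 1.5 nM, within 0.4 nM to 6 nM.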

Compound 4, inhibition constant: 3.4 nM
For compound 4 the middle estimate is 2.3-fold (0.36 log units) below the measured one; low and high end bracket the measured number.
By their numbers in this assay, from the lowest: compound 1; then compound 2; then compound 4. At a limit, above all of these: compound 3.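

Among the compounds shown here, all the earlier steps changed the aryl on the ring nitrogen, so they said nothing about the phenyl on the shared core. In this assay, replacing that phenyl with 4-methoxyphenyl gives a 3.1-fold higher number from compound 2 to compound 4 (0.50 log units; beyond the scatter) and thus a modest weakening, which shows that this position does respond to a methoxy group. That step is still much smaller than an at least 9200-fold higher number from compound 2 to compound 3 (3.96 log units; beyond the scatter) at the ring nitrogen, so the core phenyl accepts the added group far better than the aryl on the ring nitrogen accepts its change.

From the compounds shown here alone, it remains open whether a fluorine, a hydroxyl or an amine in this place would shift the number in the same way. The data shown offer no reason for the step itself.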